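Working notes: amino in place of chloro on the core

The compounds below may be only part of what the source reports. "The series", "measured", "known", "first", "only" and "open" are said of these compounds alone.

For the measured compounds named here, in a functional assay on OVCAR-5 cells (Homo sapiens) for cytotoxicity, read by sulforhodamine B assay, with a stated time of 48 h (on this read-out higher numbers stand for lower toxicity in this test and lower numbers for higher toxicity in this test), compound 1 `ClCc1ccccc1Cn1cnc2c(Cl)nc(Cl)nc21` gives 5620 nM, the lowest of the two numbers measured so far. Going by the values given here, compound 2 `ClCc1cccc(Cn2cnc3c(Cl)nc(Cl)nc32)c1` gives 47900 nM in this assay, a higher number that lies beyond the scatter; no step between these two compounds has been worked out, so only the two values themselves are set side by side.

Compound 3 `Nc1nc(Cl)c2ncn(Cc3ccccc3CCl)c2n1` is not yet measured. It differs from compound 1 by amino in place of chloro on an aromatic carbon. Among the compounds with values here, no measured pair in the set shows the outcome of such a change, so no step can be drawn from data. The expectation is a moderate rise in the number, that is lower toxicity, with compound 3 estimated at 11000 nM and a range from 3500 nM to 40000 nM. The expected step is a 2.0-fold higher number from compound 1 to compound 3 (0.29 log units; within the scatter), which may also turn out to lie within the scatter.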

Compound 3, concentration lethal to 50% of the cells: 79400 nM
The estimate for compound 3 lay 7.2-fold (0.86 log units) below the measured number; the whole stated range lies below it.
By their numbers in this assay, from the lowest: compound 1; then compounds 2 and 3 (each within the scatter of the next).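

In this assay, for the compounds shown here, this is the first single change that can be read: amino in place of chloro on the aromatic carbon between two ring nitrogen atoms gives a 14-fold higher number from compound 1 to compound 3 (1.15 log units; beyond the scatter) and so moves the read-out toward lower toxicity in this test. The low number of compound 1 therefore depends strongly on the chloro group at this place, even though the other chloro group on the shared core remains in compound 3. The data at hand give no explanation for the size of this step.

From the compounds shown here alone, it remains open whether a methoxy or a methylamino group at this place would behave like chloro or like amino. Also open, going by these compounds, is whether amino in place of chloro gives a step of similar size in compound 2, and what the same change does at the other chloro group on the core.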